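From compound 2 to compound 3: a step behind limits

A few compounds are considered here, and "the series" means these few. Any claim that something is new, unique, unknown or untested is made for them only; others in the source may bear on it.

- compound 1 `O=C(O)c1ccc(C(=O)/C(=C\c2ccc([N+](=O)[O-])c(F)c2)SCc2ccc(Br)cc2)cc1`: < 1000 ug/mL, a limit and not a number
- compound 2 `O=C(O)c1ccc(C(=O)/C(=C\c2ccc(Br)c([N+](=O)[O-])c2)SCc2ccc(Br)cc2)cc1`: < 1000 ug/mL, a limit and not a number

In a physicochemical assay for solubility (a higher number here means a more soluble compound, a lower number a less soluble compound), compound 2 has only a limit, < 1000 ug/mL, and no exact number. The evidence for compound 1 and compound 2 amounts to the limit of < 1000 ug/mL in this assay, at which 2 of the 2 values shown sit.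

The next compound is compound 3 `O=C(O)c1ccc(C(=O)/C(=C\c2ccc(O)c(Br)c2)SCc2ccc(Br)cc2)cc1`, where 3-bromo-4-hydroxyphenyl takes the place of 4-bromo-3-nitrophenyl on a double-bonded chain carbon bound to a double-bonded chain carbon (3-bromo-4-hydroxyphenyl in place of 4-bromo-3-nitrophenyl on a double-bonded chain carbon bound to a double-bonded chain carbon).

Among the compounds with values here, one measured step bears on this change, a step that the two limits leave unreadable from compound 1 to compound 2, made at the same place. Its size cannot be read, so it offers no guide to size or direction. The expected change in this assay is a step that the limit leaves unreadable from compound 2 to compound 3, an estimate with no firm direction behind it. Compound 3 is expected at 300 ug/mL, with an estimated range from 30 ug/mL to 1000 ug/mL.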

Compound 3, solubility: < 1000 ug/mL
Compound 3: only a limit was reported; the forecaster's own chance of this, stated with the estimate: 75%; the middle value lies beyond the limit too.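

In this assay compound 3 gives < 1000 ug/mL, a limit and not a number. No step among compound 1, compound 2 and compound 3 can be read, since all three stop at the same limit: the limit of < 1000 ug/mL in this assay, at which 3 of the 3 values shown sit.

Going by these compounds, the exact solubility of each compound, and whether swapping these substituted phenyl groups changes it at all, stays open.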